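Nitro for Methyl on the Pyridyl Arm of a Dihydropyridine

A few compounds are considered here, and "the series" means these few. Any claim that something is new, unique, unknown or untested is made for them only; others in the source may bear on it.

The account begins with two measured compounds. Compound 1 `CCO/C(O)=C1/C(C)=NC(C)=C([N+](=O)[O-])C1c1cccc(C)n1` was tested in a functional assay (muscle tissue) with Cavia porcellus as the target (on this read-out lower numbers stand for stronger inhibition and higher numbers for weaker inhibition), and gives 17200 nM. Compound 2 `CC1=NC(C)=C([N+](=O)[O-])C(c2ncccc2C)/C1=C(/O)OCCc1ccccc1`, which carries a phenethyl ester instead of an ethyl ester and a 3-methylpyridin-2-yl group in place of the 6-methylpyridin-2-yl group, gives 5430 nM in this assay. Among the two numbers known, compound 2 holds the lower one, and its gap to compound 1 lies beyond the scatter of the method.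

Compound 3 `CC1=NC(C)=C([N+](=O)[O-])C(c2ncccc2[N+](=O)[O-])/C1=C(/O)OCCc1ccccc1` is not yet measured. It follows from compound 2 by a single change: nitro in place of methyl on an aromatic carbon, ortho to a large group and two atoms from the ring nitrogen. Among the compounds with values here, no measured pair in this set shows this change, so its size is uncertain. The author nonetheless expects a step in the direction of stronger inhibition, clearly beyond the scatter, written as a 7.8-fold lower number from compound 2 to compound 3 (0.89 log units; beyond the scatter). For compound 3 the estimate in this assay is 700 nM, with a range from 150 nM to 3000 nM.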

Compound 3, half-maximal inhibitory concentration: 77700 nM
Compound 3: middle estimate off by 110-fold (2.05 log units), on the low side, outside the stated range (above it).
By their numbers in this assay, from the lowest: compound 2; then compound 1; then compound 3.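

Nitro in place of methyl on an aromatic carbon, ortho to a large group and two atoms from the ring nitrogen, gives a 14-fold higher number from compound 2 to compound 3 (1.16 log units; beyond the scatter) in this assay, a large step towards weaker inhibition. Within the data shown here, this is the first pair in the account that differs in one place, so it gives the first direct reading of this position: with the phenethyl ester and the rest of the core held fixed, the 3-methylpyridin-2-yl arm of compound 2 inhibits more strongly than the 3-nitropyridin-2-yl arm of compound 3, and what stands at this place clearly matters. Nothing in the available data explains the size or direction of this step.

The compounds shown leave open whether the loss is particular to nitro or would also appear with another group at this place, such as an amine, a chlorine atom or a methoxy group, and how a plain hydrogen there would compare with methyl. They also leave open whether the same change would give a step of similar size with an ethyl ester in place of the phenethyl ester.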